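An Ester Arm Added to the Core of Compound 1

The source may report more compounds than this note shows. Statements on the series, on what has been measured and on what is new or still open speak of the compounds shown alone.

Compound 1 `Cc1cc2c(cc1C)[n+]([O-])nn2C` — > 100 ug/mL
Compound 2 `CC1=CC(=O)c2nn(C)nc2C1=O` — 0.3 ug/mL
Compound 3 `COC(=O)C(C)n1nc2c(n1)C(=O)C(C)=C(C)C2=O` — 0.9 ug/mL

In a functional assay on HeLa cells (Homo sapiens) for inhibition, read by colorimetric assay, with a stated time of 72 h (a lower number here means that less compound is needed, a higher number that more compound is needed for the effect), compound 1 reaches only a limit, > 100 ug/mL; this is the limit of > 100 ug/mL in this assay, at which 1 of the 3 values shown sits. Compound 2 gives 0.3 ug/mL and compound 3 gives 0.9 ug/mL, but both are built on a core unlike that of compound 1, so neither speaks to its kind. Compound 4 `COC(=O)Cn1n[n+]([O-])c2cc(C)c(C)cc21` differs from compound 1 by methoxycarbonyl in place of hydrogen on a saturated chain carbon bound to an aromatic nitrogen. Among the measured compounds shown here, no measured pair shows this change, so the expectation rests on compound 1 alone, whose core is untouched. Compound 4 is expected to show a number no higher from compound 1 to compound 4 (the limit leaves the size open), that is, nothing beyond the scatter. Compound 4 is thus estimated at 100 ug/mL, within 30 ug/mL to 300 ug/mL, most probably again only a limit.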

Compound 4, concentration for half-maximal effect: > 100 ug/mL
Compound 4 was reported as a limit; the forecaster's own chance of this, stated with the estimate: 80%; the middle value lies on the limit itself.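

Compound 1 and compound 4 each stand only at a limit in this assay, so no step can be read between them: the limit of > 100 ug/mL in this assay, at which 2 of the 4 values shown sit. From the compounds shown here alone, what methoxycarbonyl in place of hydrogen does to the number on this core stays open.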